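Urea series on the shared core: trifluoromethyl to chloro

A few compounds are considered here, and "the series" means these few. Any claim that something is new, unique, unknown or untested is made for them only; others in the source may bear on it.

Measured so far in a functional assay on MDA-MB-231 cells (Homo sapiens) for inhibition, read by sulforhodamine B assay, with a stated time of 48 h, tested at 10 uM; a higher number here means a weaker effect of the compound at the concentration tested, a lower number a stronger effect:
compound 1 `COc1cc(Cl)cc(-c2nn(-c3cccc(NC(=O)c4ccc(Cl)c(Cl)c4)c3)cc2-c2ccncc2)c1`: 33.9%
compound 2 `O=C(Nc1cccc(-n2cc(-c3ccncc3)c(-c3cc(O)cc(Cl)c3)n2)c1)Nc1ccc(Cl)c(Cl)c1`: -38.1%
compound 3 `COc1cc(Cl)cc(-c2nn(-c3cccc(NC(=O)Nc4ccc(Cl)c(C(F)(F)F)c4)c3)cc2-c2ccncc2)c1`: -30.8%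

Compound 3 stands second highest of the three numbers; compound 2 lies within the scatter of it, while compound 1 lies far above it. Compound 4 `COc1cc(Cl)cc(-c2nn(-c3cccc(NC(=O)Nc4ccc(Cl)c(Cl)c4)c3)cc2-c2ccncc2)c1` is not yet measured. The change from compound 3 is chloro in place of trifluoromethyl on an aromatic carbon. Going by the values given here, the one measured step, a number 64.7 percentage points lower from compound 1 to compound 3 (beyond the scatter), alters two parts at once and does not isolate this change. The same (3,4-dichlorophenyl)amino urea as in compound 4 is carried by compound 2, which gives -38.1% in this assay, close to compound 3. The step is therefore expected to be small: a number 3.2 percentage points lower from compound 3 to compound 4 (within the scatter) is the estimated change, within the scatter. Compound 4 is expected to give about -34%, in the range -58% to -10%.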

Compound 4, a percentage reported as activity, at one concentration (the size of the read-out at that concentration, not a potency): -21%
Estimate against measurement, compound 4: 13 percentage points below, within the range that was stated.
By their numbers in this assay, from the lowest: compounds 2, 3 and 4 (each within the scatter of the next, the first and the last beyond it); then compound 1.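

In this assay, going by these compounds alone, chloro in place of trifluoromethyl, on an aromatic carbon ortho to a chloro group, gives a number 9.8 percentage points higher from compound 3 to compound 4 (within the scatter) as the first isolated reading of this change. With the aryl group held, the carbonyl-linked change now stands alone: (3,4-dichlorophenyl)amino in place of 3,4-dichlorophenyl gives a number 54.9 percentage points lower from compound 1 to compound 4 (beyond the scatter) in a single place. With the urea held, methyl in place of hydrogen on the oxygen gives a number 17.1 percentage points higher from compound 2 to compound 4 (beyond the scatter) as a modest step.

No measurement here accounts for any of these steps.
Still open, as far as these compounds go, is how an amine or a carboxylic acid on this aromatic carbon would read against chloro and trifluoromethyl.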